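Aryl swap on the shared core: compound 3 to compound 4

This account rests on a few compounds, and the source may have more. Where it says the series, first, only, none or still open, it means among the compounds named here.

Compound 1 `Cc1cc(-c2c(O)nc3cc(Cl)c([N+](=O)[O-])cc3c2OCCC2CCCCN2)cc(C(C)O)c1` gives 63 nM in a functional assay on cells (Pituitary gland cell) for antagonist activity at Gonadotropin-releasing hormone receptor (Rattus norvegicus); a higher number here means a weaker inhibitor, a lower number a stronger inhibitor. Compound 2 `O=[N+]([O-])c1cc2c(OCCC3CCCCN3)c(-c3cccc(Cl)c3)c(O)nc2cc1Cl` gives 40 nM in this assay, and compound 3 `O=[N+]([O-])c1cc2c(OCCC3CCCCN3)c(-c3ccc4ccccc4c3)c(O)nc2cc1Cl` gives 53 nM in this assay. Compound 3 stands second highest of the three numbers; its nearest number is reached by a 1.2-fold lower number from compound 1 to compound 3 (0.08 log units; within the scatter) and its furthest by a 1.3-fold higher number from compound 2 to compound 3 (0.12 log units; within the scatter), both within the scatter. Compound 4 `O=[N+]([O-])c1cccc(-c2c(O)nc3cc(Cl)c([N+](=O)[O-])cc3c2OCCC2CCCCN2)c1` carries 3-nitrophenyl in place of naphthalen-2-yl on an aromatic carbon. The steps bearing on this change are the earlier aryl swaps on the same carbon, a 1.6-fold lower number from compound 1 to compound 2 (0.20 log units; within the scatter), a 1.2-fold lower number from compound 1 to compound 3 (0.08 log units; within the scatter) and a 1.3-fold higher number from compound 2 to compound 3 (0.12 log units; within the scatter), none of which moved this assay beyond the scatter. No step beyond the scatter is therefore expected for a 1.1-fold lower number from compound 3 to compound 4 (0.03 log units; within the scatter). Compound 4 is estimated at 50 nM, with a range of 20 nM to 130 nM in this assay.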

Compound 4, half-maximal inhibitory concentration: 100 nM
For compound 4 the middle estimate is 2.0-fold (0.30 log units) below the measured one, within the range that was stated.
By their numbers in this assay, from the lowest: compounds 2, 3, 1 and 4 (each within the scatter of the next, the first and the last beyond it).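

Going by these compounds alone, at this aryl position, nitro in place of chloro gives the only step beyond the scatter in this set of compounds, a modest one in this assay (a 2.5-fold higher number from compound 2 to compound 4 (0.40 log units; beyond the scatter)). The other two new steps stay within the scatter (a 1.9-fold higher number from compound 3 to compound 4 (0.28 log units; within the scatter); a 1.6-fold higher number from compound 1 to compound 4 (0.20 log units; within the scatter)), so the aryl change separates only compound 2 and compound 4. No available data account for this step.

Open, going by these compounds, is whether an amine or a carboxylic acid in place of that nitro group would track compound 2 or compound 4. Also open, on these data alone, is whether the step from chloro to nitro holds on any other aryl group.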